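The source may report more compounds than this note shows. Statements on the series, on what has been measured and on what is new or still open speak of the compounds shown alone.

Measured in a functional assay on MC-38 cells (Mus musculus) for antiproliferative activity, read by CCK-8 assay, with a stated time of 48 h; a higher number here means a weaker inhibitor, a lower number a stronger inhibitor:
- Compound 1 `COc1ccc(/C=C\c2cc(OC)c(OC)c(OC)c2)cc1OCc1ccc(CN2CCCC[C@@H]2C(=O)O)cc1`: > 10000 nM, a limit
- Compound 2 `COc1ccc(/C=C\c2cc(OC)c(OC)c(OC)c2)cc1OCc1ccc(CN[C@H](C(=O)O)[C@H](C)O)cc1`: > 10000 nM, a limit
- Compound 3 `COc1ccc(/C=C\c2cc(OC)c(OC)c(OC)c2)cc1OCc1ccc(CO)cc1`: 5700 nM

Going by the values given here, compound 3 holds the only true number in this set, 5700 nM. The other two compounds stand at the limit of > 10000 nM in this assay, at which 2 of the 3 values shown sit.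

Compound 4 `COc1ccc(/C=C\c2cc(OC)c(OC)c(OC)c2)cc1OCc1ccc(CN2CC(C(=O)O)C2)cc1` keeps the shared core of compound 3 and carries 3-carboxyazetidin-1-yl in place of hydroxy on a saturated chain carbon bound to an aromatic carbon.

Among the compounds with values here, two measured steps bear on this change, since both concern the same place and both link the hydroxy group to a carboxy-bearing amine group. They are an at least 1.7-fold lower number from compound 1 to compound 3 (0.24 log units; that floor lies within the scatter) and an at least 1.7-fold lower number from compound 2 to compound 3 (0.24 log units; that floor lies within the scatter). Neither gives a true size, but compound 1 and compound 2 both point the same way, so a move to a higher number is expected for the reverse kind of exchange.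

The expected step is a 2.1-fold higher number from compound 3 to compound 4 (0.32 log units; beyond the scatter), and the reading may well end at a limit.

For compound 4 the estimate is 12000 nM, with an expected range of 5000 nM to 30000 nM.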

Compound 4, half-maximal inhibitory concentration: > 10000 nM
Compound 4 was reported as a limit; the forecaster's own chance of this, stated with the estimate: 65%; the middle value lies beyond the limit too.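

From the compounds shown here alone, with 3-carboxyazetidin-1-yl, a third carboxy-bearing amine group on this saturated chain carbon bound to an aromatic carbon joins 2-carboxypiperidin-1-yl and (1-carboxy-2-hydroxypropyl)amino without giving a true number in this assay, so a change in the amine part of the group has still produced no readable value: the limit of > 10000 nM in this assay, at which 3 of the 4 values shown sit. Replacing hydroxy gives an at least 1.7-fold higher number from compound 3 to compound 4 (0.24 log units; that floor lies within the scatter), but that floor lies within the scatter, so the true size of the change remains unknown. The steps linking compound 4 with compound 1 and compound 2 cannot be read, since all three values are limits.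

The compounds shown leave open how a plain amine without the carboxylic acid would read at this place. They also leave open whether a methyl ester of the acid, or a longer chain carrying it, would give a true number.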